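Removing the 1,3-thiazol-2-yl group from compound 2

The source may report more compounds than this note shows. Statements on the series, on what has been measured and on what is new or still open speak of the compounds shown alone.

Within the data shown here, in a functional assay on MDA-MB-435 cells (Homo sapiens) for antiproliferative activity, read by sulforhodamine B assay, with a stated time of 72 h (a higher number here means a weaker inhibitor, a lower number a stronger inhibitor), only two compounds have numbers so far. Compound 1 (`Clc1ccc(C(/C=C/c2ccccc2)=N\Nc2nncc3ccccc23)cc1`) gives 5.6 nM, and compound 2 (`O=S(=O)(Nc1nccs1)c1ccc(Nc2nncc3ccccc23)cc1`) gives 36 nM. Compound 2 thus has the higher number of the two and is the weaker inhibitor, by a gap beyond the usual scatter. The two compounds differ in more than one place, so that gap cannot be tied to any single group. Compound 3 (`NS(=O)(=O)c1ccc(Nc2nncc3ccccc23)cc1`) is still unmeasured. It has hydrogen in place of 1,3-thiazol-2-yl on a sulfonamide nitrogen. Among the measured compounds shown here, no measured pair shows the effect of this change, so the expectation is loose: a small rise in the number in this assay, possibly no larger than the scatter. The expected step is a 1.7-fold higher number from compound 2 to compound 3 (0.22 log units; within the scatter). The estimated value for compound 3 is 60 nM, with an expected range of 15 nM to 300 nM.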

Compound 3, half-maximal inhibitory concentration: 18 nM
Compound 3: middle estimate off by 3.3-fold (0.52 log units), on the high side, and the stated range covers the measured number.
By their numbers in this assay, from the lowest: compound 1; then compounds 3 and 2 (each within the scatter of the next).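

In this assay, among these compounds, compounds 2 and 3 give the first pair that differs in one place, and the step is a 2.0-fold lower number from compound 2 to compound 3 (0.30 log units; within the scatter). On this sulfonamide nitrogen, the whole 1,3-thiazol-2-yl group, a five-membered aromatic ring, can therefore give way to hydrogen with no change beyond the scatter, so this ring is not required for nanomolar antiproliferative activity in this series. No measurement here bears on why the exchange is tolerated.

As far as these compounds go, what a methyl, an acetyl or a phenyl group on the same nitrogen would do remains open. A single step also cannot show whether this tolerance extends to other groups at this position or to compounds with a different core.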